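From methoxycarbonyl to propoxycarbonyl in compound 3

The compounds below may be only part of what the source reports. "The series", "measured", "known", "first", "only" and "open" are said of these compounds alone.

Measured so far in a functional assay on A2780 cells (Homo sapiens) for antiproliferative activity, read by MTT assay, with a stated time of 48 h (a higher number here means a weaker inhibitor of growth, a lower number a stronger inhibitor of growth), for two compounds

compound 1 `COC(=O)N1N=C(c2ccccc2)CC1c1cc(OC)c(OC)c(OC)c1` gives 2770 nM
compound 2 `COC(=O)N1N=C(c2cccc(OC)c2)CC1c1cc(OC)c(OC)c(OC)c1` gives 2780 nM

Compound 2 stands level with compound 1 in this assay, as the two values lie within the scatter of each other. Compound 3 (`CCCOC(=O)N1N=C(c2cccc(OC)c2)CC1c1cc(OC)c(OC)c(OC)c1`) differs from compound 2 in one place, methoxycarbonyl to propoxycarbonyl (ethyl in place of hydrogen on a saturated chain carbon bound to an oxygen next to a carbonyl group), which is ethyl in place of hydrogen on a saturated chain carbon bound to an oxygen next to a carbonyl group. Among the measured compounds shown here, only one measured step exists, and a 1.0-fold higher number from compound 1 to compound 2 (0.00 log units; within the scatter) stayed within the scatter for methoxy in place of hydrogen on an aromatic carbon. That is a different change in a different place, so it bears on this one only loosely. For the measured compounds named here, no measured compound varies the group now being changed. The expectation is therefore of no shift beyond the scatter, held with little confidence. Estimated here is a 1.1-fold higher number from compound 2 to compound 3 (0.03 log units; within the scatter) as the likely size of the step. For compound 3 an estimate of 3000 nM is expected, with an expected range of 1200 nM to 8000 nM around it.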

Compound 3, concentration for 50% growth inhibition: > 10000 nM
Compound 3: only a limit was reported (the forecaster's own chance of this, stated with the estimate: 3%); middle value at least 3.3-fold (0.52 log units) from the limit.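

In this assay compound 3 gives > 10000 nM, which is a limit of the assay and not a number. The change from methoxycarbonyl to propoxycarbonyl gives an at least 3.5-fold higher number from compound 2 to compound 3 (0.55 log units; beyond the scatter), so this position, unlike the aromatic carbon changed in the earlier step, a 1.0-fold higher number from compound 1 to compound 2 (0.00 log units; within the scatter), is one where a single change carries the read-out beyond the scatter and toward weaker inhibition of growth. Only a lower bound on this step can be read, and its true size stays unknown, since the one compound carrying propoxycarbonyl rests on the limit: the limit of > 10000 nM in this assay, at which 1 of the 3 values shown sits.

The compounds shown leave open whether a shorter extension such as ethoxycarbonyl would already weaken growth inhibition, and whether a longer chain such as butoxycarbonyl, or a carboxylic acid or amide in place of the ester, would behave in the same way. They also leave open whether propoxycarbonyl would give a step of like size on compound 1, which lacks the methoxy group that compound 2 and compound 3 carry on the aromatic ring.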